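From dimethylphenyl to methyl on the amine nitrogen

The source may report more compounds than this note shows. Statements on the series, on what has been measured and on what is new or still open speak of the compounds shown alone.

Compound 1 `Cc1ccc(NN=C2CCC(C)n3c2ncc(C(=O)O)c3=O)cc1C` in a functional assay on the whole organism with Rattus norvegicus as the target (a lower number here means that less compound is needed, a higher number that more compound is needed for the effect), gives only a limit, > 100 umol/kg.
Compound 2 `Cc1nc2n(c(=O)c1C(=O)O)C(C)CCC2=NNc1ccccc1` in this assay likewise gives only a limit, > 320 umol/kg.

Compound 1 thus stands at the limit of > 100 umol/kg in this assay, at which 1 of the 2 values shown sits. Compound 2 stands at the limit of > 320 umol/kg in this assay, at which 1 of the 2 values shown sits. Going by the values given here, neither is a number, and no measured pair shows how any change shifts potency here. Compound 3 `CNN=C1CCC(C)n2c1ncc(C(=O)O)c2=O` is still to be measured; it differs from compound 1 by methyl in place of 3,4-dimethylphenyl on an amine nitrogen. With nothing measured to guide the direction, the step that the limit leaves unreadable from compound 1 to compound 3 is expected to fall within the scatter. Compound 3 is therefore estimated at 200 umol/kg, within a range from 50 umol/kg to 1000 umol/kg.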

Compound 3, dose for 50% inhibition: > 100 umol/kg
Compound 3 was reported as a limit; the forecaster's own chance of this, stated with the estimate: 80%; the middle value does not contradict the limit.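

Compound 1 and compound 3 each give only a limit, so no step can be read between them: the limit of > 100 umol/kg in this assay, at which 2 of the 3 values shown sit.

Going by these compounds, whether swapping 3,4-dimethylphenyl for methyl on the amine nitrogen changes the dose needed at all remains open.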